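The source may report more compounds than this note shows. Statements on the series, on what has been measured and on what is new or still open speak of the compounds shown alone.

Among the measured compounds shown here, compound 2 `CCNC(=O)c1noc(-c2cc(C(C)C)c(O)cc2O)c1-c1cc(C(N)=O)no1` is the only member of the series with a number: in a functional assay on A2780 cells (Homo sapiens) for inhibition (on this read-out higher numbers stand for weaker inhibition and lower numbers for stronger inhibition), compound 2 gives 15 nM, and compound 1 `CCNC(=O)c1noc(-c2cc(C(C)C)c(O)cc2O)c1-c1cc(CNC(C)=O)no1` carries "not determined" (no result reported) in this assay. Compound 3 `CCNC(=O)c1noc(-c2cc(C(C)C)c(O)cc2O)c1-c1cnn(CC)c1` is not yet measured. Its change from compound 2 is 1-ethyl-1H-pyrazol-4-yl in place of 3-carbamoyl-1,2-oxazol-5-yl on an aromatic carbon. For the measured compounds named here, no step between measured compounds exists to anchor this change, so the expected direction rests on compound 2 alone; a moderate weakening beyond the scatter is expected, as a 2.7-fold higher number from compound 2 to compound 3 (0.43 log units; beyond the scatter) expresses. For compound 3 the estimate is 40 nM, with a range of 12 nM to 130 nM.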

Compound 3, half-maximal inhibitory concentration: 30 nM
The estimate for compound 3 lay 1.3-fold (0.12 log units) above the measured number; low and high end bracket the measured number.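

In this assay, 1-ethyl-1H-pyrazol-4-yl in place of 3-carbamoyl-1,2-oxazol-5-yl on this aromatic carbon gives a 2.0-fold higher number from compound 2 to compound 3 (0.30 log units; within the scatter). This position therefore tolerates the exchange of the carbamoyl-bearing ring for an ethyl-bearing one, with the read-out of compound 3 within the scatter of compound 2. No measurement at hand accounts for this result. Open, as far as these compounds go, is whether a carboxylic acid in place of the carbamoyl group would keep this read-out. Also open, from the compounds shown here alone, is how a longer chain, such as butyl, or an aminoethyl chain would fare in place of the ethyl group on the pyrazole.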